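This account rests on a few compounds, and the source may have more. Where it says the series, first, only, none or still open, it means among the compounds named here.

Measured compounds:
compound 1, `[N-]=[N+]=NCCOCCOCCO[Si]1(OCCOCCOCCN=[N+]=[N-])n2c3c4ccccc4c2/N=C2\N=C(/N=c4/c5ccccc5/c(n41)=N/C1=N/C(=N\3)c3ccccc31)c1ccccc12`: 7.9 nM
compound 2, `[N-]=[N+]=NCCOCCO[Si]1(OCCOCCO)n2c3c4ccccc4c2/N=C2\N=C(/N=c4/c5ccccc5/c(n41)=N/C1=N/C(=N\3)c3ccccc31)c1ccccc12`: 2.2 nM

Both were tested in a functional assay on HT-29 cells (Homo sapiens) for cytotoxicity, read by MTT assay, with a stated time of 24 h; a lower number here means a stronger inhibitor, a higher number a weaker inhibitor. Of the two numbers, compound 2 has the lower one; compound 1 gives a number that is higher by a margin beyond the usual scatter, so compound 2 stands as the stronger inhibitor of this pair on the evidence at hand. For the measured compounds named here, no single-point step connects the two, as they differ in more than one place, so nothing more is read from their gap.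

Compound 3, `[N-]=[N+]=NCCOCCO[Si]1(OCCOCCN=[N+]=[N-])n2c3c4ccccc4c2/N=C2\N=C(/N=c4/c5ccccc5/c(n41)=N/C1=N/C(=N\3)c3ccccc31)c1ccccc12`, has not yet been measured. It differs from compound 2 by azido in place of hydroxy on a saturated chain carbon, two bonds along the chain from an oxygen on a saturated carbon. Going by the values given here, since no step for this exact change is known among the measured compounds, the expectation rests only on the two values shown. Compound 3 is expected to give a number somewhat higher than that of compound 2, with an estimated step of a 2.0-fold higher number from compound 2 to compound 3 (0.31 log units; beyond the scatter) in this assay, a shift that may or may not exceed the scatter. For compound 3 the estimate in this assay is 4.5 nM, with a likely range from 1.5 nM to 14 nM.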

Compound 3, half-maximal inhibitory concentration: 7.1 nM
Compound 3: the middle estimate sits 1.6-fold (0.20 log units) below what was measured; low and high end bracket the measured number.
By their numbers in this assay, from the lowest: compound 2; then compounds 3 and 1 (each within the scatter of the next).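

In this assay, the step from hydroxy to azido on a saturated chain carbon, two bonds along the chain from an oxygen on a saturated carbon, is the only change among these compounds that can be read at a single place, and it gives a 3.2-fold higher number from compound 2 to compound 3 (0.51 log units; beyond the scatter). This shows that the hydroxy end of compound 2 is not neutral at this position, although the change is modest and compound 3, with azido at both chain ends, remains active at 7.1 nM. Nothing shown here accounts for the size or direction of this step.

On these data alone, whether the effect belongs to the loss of hydroxy or to the arrival of azido stays open, and an amine, a carboxylic acid or a methoxy group at the same chain end would be needed to tell these apart. For the compounds shown here, the effect of a longer chain alone also remains unresolved, since compound 1 differs from compound 2 and compound 3 in more than one place and gives no single-place step.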